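Benzylsulfanyl for propylsulfanyl on the shared core

A few compounds are considered here, and "the series" means these few. Any claim that something is new, unique, unknown or untested is made for them only; others in the source may bear on it.

Three analogues of one core have numbers in a functional assay on ECa-109 cells (Homo sapiens) for antiproliferative activity, read by MTT assay, with a stated time of 72 h; a lower number here means a stronger inhibitor, a higher number a weaker inhibitor. Compound 1 `C#CCSc1nc(N/N=C(\C)c2ccccc2O)c2nnn(Cc3ccccc3)c2n1` gives 5250 nM; compound 2 `CCCSc1nc(N/N=C(\C)c2ccccc2O)c2nnn(Cc3ccccc3)c2n1` gives 11100 nM; compound 3 `CCCSc1nc(N/N=C(\C)c2ccccc2O)c2nnn(Cc3ccc(F)cc3)c2n1` gives 21900 nM. Compound 2 therefore sits above compound 1 by a 2.1-fold higher number from compound 1 to compound 2 (0.33 log units; beyond the scatter), while compound 2 and compound 3 cannot be told apart, since a 2.0-fold higher number from compound 2 to compound 3 (0.30 log units; within the scatter) lies within the scatter.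

Compound 4 `C/C(=N\Nc1nc(SCc2ccccc2)nc2c1nnn2Cc1ccccc1)c1ccccc1O` differs from compound 2 by phenyl in place of ethyl on a saturated chain carbon bound to a sulfur. Going by the values given here, the only measured step at the same place is a 2.1-fold higher number from compound 1 to compound 2 (0.33 log units; beyond the scatter), a modest move that came with a different small change on that carbon. The other step, a 2.0-fold higher number from compound 2 to compound 3 (0.30 log units; within the scatter), concerns the aromatic ring and does not bear on this change. Among the compounds with values here, no measured pair shows a phenyl entering on a saturated chain carbon bound to a sulfur, so the expected step is small and of uncertain direction, most likely not beyond the scatter; the estimated step is a 1.2-fold lower number from compound 2 to compound 4 (0.09 log units; within the scatter).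

Compound 4 is accordingly expected to give about 9000 nM in this assay, with a range from 3000 nM to 27000 nM.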

Compound 4, half-maximal inhibitory concentration: 1770 nM
Estimate against measurement, compound 4: 5.1-fold (0.71 log units) above; the measured number lies below the stated range.
By their numbers in this assay, from the lowest: compound 4; then compound 1; then compounds 2 and 3 (each within the scatter of the next).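

In this assay, going by these compounds alone, the substituent on this saturated chain carbon bound to a sulfur moves the number further than the one earlier step there suggested: propylsulfanyl to benzylsulfanyl gives a 6.3-fold lower number from compound 2 to compound 4 (0.80 log units; beyond the scatter) and phenyl in place of ethynyl gives a 3.0-fold lower number from compound 1 to compound 4 (0.47 log units; beyond the scatter). With the benzyl group on the shared core held constant, the three groups on this carbon now fall in a clear order, with phenyl giving the lowest number, then ethynyl, then ethyl. No evidence at hand explains why phenyl gives this result.

The compounds shown do not separate the aromatic ring from simple chain length, which a cyclohexyl ring or a longer chain such as pentyl on this carbon would address. On these data alone, whether a fluoro or methoxy group on the entering phenyl keeps the lower number also remains open.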